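The source may report more compounds than this note shows. Statements on the series, on what has been measured and on what is new or still open speak of the compounds shown alone.

Measured so far in an ADME assay on J774 cells (Mus musculus) for cytotoxicity; a higher number here means that more compound is needed for the effect, a lower number that less compound is needed:
- Compound 1 `CCCCc1cc2c(=O)c(C(=O)OC)c[nH]c2cc1OCCOc1ccccc1`: > 20000 nM
- Compound 2 `CCCCc1cc2c(=O)c(C(=O)NC(C)C)c[nH]c2cc1OCCOc1ccccc1`: > 20000 nM

Compound 2 stands at > 20000 nM, which is a limit of the assay and not a number. Compound 1 shares this position, as the record shows (the limit of > 20000 nM in this assay, at which 2 of the 2 values shown sit). Among the measured compounds shown here, the only measured step is a step that the two limits leave unreadable from compound 1 to compound 2, so it offers no size to carry forward.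

Compound 3 `CCCCc1cc2c(=O)c(I)c[nH]c2cc1OCCOc1ccccc1` differs from compound 2 in one place: iodo in place of isopropylcarbamoyl on an aromatic carbon. Iodo takes the place of isopropylcarbamoyl on an aromatic carbon. Both measured compounds sit at the limit, so there is no measured basis for expecting a change beyond the scatter in either direction, although a readable number remains possible. The expected step is a number no higher from compound 2 to compound 3 (the limit leaves the size open). For compound 3 the estimate is 20000 nM, with an expected range from 8000 nM to 50000 nM.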

Compound 3, half-maximal effective concentration: > 10000 nM
Compound 3 was reported as a limit; the forecaster's own chance of this, stated with the estimate: 70%; the middle value is on the limit's open side.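

Compound 3, like compound 1 and compound 2, is reported only as a limit of the assay, and no size can be read for any step among them. The compounds shown leave open what concentration each one needs in this assay, and whether they differ at all.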